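The source may hold more compounds than are shown below. What is called first, only, known or untested is meant among the compounds shown, and "the series" means these compounds.

Working notes on the series. Compound 3 `CN(C)CCCCCSC1=Nc2ccccc2C(CC(=O)NCc2ccc(F)cc2)N1c1ccccc1` has no position on the scale: in an assay on cells for inhibition of Voltage-dependent T-type calcium channel subunit alpha-1I (Homo sapiens), read by patch clamp, tested at 10 uM (a higher number here means more inhibition at the concentration tested (going by the name of the read-out), a lower number less inhibition), compound 3 is reported as "not active" (no number reported) and no number is attached, so it cannot be placed against the two measured neighbours. Compound 1 `CN(C)CCCCCSC1=Nc2ccccc2C(CC(=O)NCc2ccccc2)N1c1ccc(-c2ccc(F)cc2)cc1` gives 66.7% in this assay. Compound 2 `CN(C)CCCCCSC1=Nc2ccccc2C(CC(=O)NCc2ccccc2)N1c1ccc(-c2ccccc2)cc1` gives 85.6% in this assay.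

Compound 4 `CN(C)CCCCCSC1=Nc2ccccc2C(CC(=O)NCc2ccccc2)N1c1ccccc1` differs from compound 3 by hydrogen in place of fluoro on an aromatic carbon. One measured step is of the same kind, though it sits on a different part of the molecule: a number 18.9 percentage points higher from compound 1 to compound 2 (beyond the scatter). Within the data shown here, that step was modest and upward, and it is the only guide available, since the other two compounds carry a different aryl group on the core and no direct comparison to compound 3 exists. Read across, the change from compound 3 to compound 4 might lift the inhibition number in this assay by a similar modest amount, but from a starting point that is reported as not active with no number attached, so the number expected for compound 4 in this assay is at the low end of the scale, and a second verdict of reported as not active is a real possibility.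

The expected value of compound 4 in this assay is 22%, with a range from 0% to 50%.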

Compound 4, a percentage reported as inhibition, at one concentration (the size of the read-out at that concentration, not a potency): 76%
The estimate for compound 4 lay 54 percentage points below the measured number; the whole stated range lies below it.
By their numbers in this assay, from the lowest: compounds 1, 4 and 2 (each within the scatter of the next, the first and the last beyond it).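

In this assay compound 3 is reported as "not active" (no number reported) and compound 4 gives 76%, so on the benzyl ring, para to a large group, fluoro against hydrogen separates a verdict without a number from a clear reading, although no numerical step can be read for this pair. The outer aryl ring of compound 1 and compound 2 also proves unnecessary for a reading in this range: a number 9.6 percentage points lower from compound 2 to compound 4 (within the scatter) and a number 9.3 percentage points higher from compound 1 to compound 4 (within the scatter) both lie within the scatter. The same exchange of fluoro for hydrogen on the outer ring gave only a number 18.9 percentage points higher from compound 1 to compound 2 (beyond the scatter), and no measurement available explains why the two places differ.

Whether the loss goes with fluoro alone stays open, since the compounds shown carry no chloro, methyl or methoxy in that place on the benzyl ring. Also open is how much the basic end contributes, as every compound shown ends in the same dimethylamino group and none carries a pyrrolidine or a morpholine there.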